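The source may hold more compounds than are shown below. What is called first, only, known or untested is meant among the compounds shown, and "the series" means these compounds.

Working notes on the series.

Compound 1 is `CSCC[C@H](NC(=O)c1ccc(NCc2cncn2Cc2cccc(C)c2)cc1-c1ccccc1)C(=O)O`. In a functional assay on NIH3T3 cells (Mus musculus) (on this read-out higher numbers stand for an effect only at larger amounts of compound and lower numbers for an effect already at smaller amounts), compound 1 reaches only the assay limit, > 10 uM. Compound 2 is `CSCC[C@H](NC(=O)c1ccc(NCc2cncn2Cc2ccc(C#N)cc2)cc1-c1ccccc1)C(=O)O`; it keeps the shared core and carries 4-cyanophenyl in place of 3-methylphenyl on a saturated chain carbon bound to an aromatic nitrogen. In this assay compound 2 again reaches only the limit, > 10 uM. Compound 3 is `N#Cc1ccc(Cn2cncc2CNc2ccc(C(=O)Nc3cccc(C#N)c3)c(-c3ccccc3)c2)cc1`, with 3-cyanophenyl in place of 1-carboxy-3-(methylsulfanyl)propyl on the amide-type nitrogen. In this assay compound 3 also stops at the limit, > 10 uM.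

The two measured steps are therefore a step that the two limits leave unreadable from compound 1 to compound 2 and a step that the two limits leave unreadable from compound 2 to compound 3; neither can be sized, since both ends sit at the same limit. Where compound 2 stands on the numbers shown is only a limit, and the two further values are limits as well, as summed up in the limit of > 10 uM in this assay, at which 3 of the 3 values shown sit.

Compound 4 is `CSCC[C@H](NC(=O)c1ccc(NCc2cncn2Cc2ccc([N+](=O)[O-])cc2)cc1-c1ccccc1)C(=O)O`. It differs from compound 2 by nitro in place of cyano on an aromatic carbon. Within the data shown here, no measured step touches this position with a readable size, so nothing here supports a change beyond the scatter in either direction. The expected step from compound 2 to compound 4 is a step that the limit leaves unreadable from compound 2 to compound 4, and compound 4 is estimated at 20 uM in this assay, with a range from 5 uM to 80 uM.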

Compound 4, concentration for half-maximal effect: > 10 uM
Compound 4: no number, only a limit; the forecaster's own chance of this, stated with the estimate: 85%; the middle value is on the limit's open side.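

Compound 4 with > 10 uM in this assay again reaches only a limit of the assay, so no new step can be read from compound 1 or from compound 2 to compound 4. With only limits on record, the compounds shown leave open whether any of these exchanges shifts the read-out, and in which direction.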